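This account rests on a few compounds, and the source may have more. Where it says the series, first, only, none or still open, it means among the compounds named here.

Compound 1 `CN1C[C@H](C(=O)Nc2ccc(C3CC3)cc2)[C@@H](c2ccc(/C=C/C(=O)Nc3ccccc3N)cc2)C1` carries a 4-cyclopropylphenyl group on an amide-type nitrogen. In an in vitro ADME assay on microsomes from liver (Mus musculus) for pharmacokinetics, read by LC-MS, with a stated time of 10 min, tested at 1 uM (on this read-out lower numbers stand for slow clearance and higher numbers for fast clearance), compound 1 gives 60 mL/min/kg. Two close relatives have been run in the same test: compound 2 `CN1C[C@H](C(=O)Nc2cccc(Cl)c2)[C@@H](c2ccc(/C=C/C(=O)Nc3ccccc3N)cc2)C1` gives 58 mL/min/kg, and compound 3 `CN1C[C@H](C(=O)Nc2ccc(F)c(Br)c2)[C@@H](c2ccc(/C=C/C(=O)Nc3ccccc3N)cc2)C1` gives 43 mL/min/kg. The three numbers are not separated from one another: the step of a 1.0-fold lower number from compound 1 to compound 2 (0.01 log units; within the scatter) and the step of a 1.4-fold lower number from compound 1 to compound 3 (0.14 log units; within the scatter) both sit within the usual scatter, as does the step of a 1.3-fold lower number from compound 2 to compound 3 (0.13 log units; within the scatter), so compound 1 cannot be set apart from compound 2 or compound 3 on these numbers.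

Compound 4 `CN1C[C@H](C(=O)Nc2ccc(Cl)cn2)[C@@H](c2ccc(/C=C/C(=O)Nc3ccccc3N)cc2)C1` has not yet been measured. Among the measured compounds shown here, its single change from compound 1 is 5-chloropyridin-2-yl in place of 4-cyclopropylphenyl on an amide-type nitrogen. For the measured compounds named here, the only steps that bear on this change are the three swaps of one aromatic group for another on the same amide-type nitrogen, and none of them moved the clearance number beyond the scatter. A ring with one hetero atom has not been tried here, so the expectation rests on those three swaps alone. The step of a 1.2-fold lower number from compound 1 to compound 4 (0.08 log units; within the scatter) is therefore expected to stay within the scatter, in no particular direction. Compound 4 is estimated to give 50 mL/min/kg in this assay, between 28 mL/min/kg and 90 mL/min/kg.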

Compound 4, clearance: 31 mL/min/kg
Compound 4: middle estimate off by 1.6-fold (0.21 log units), on the high side; low and high end bracket the measured number.
By their numbers in this assay, from the lowest: compounds 4, 3, 2 and 1 (each within the scatter of the next).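

Across the four aromatic groups now seen on this amide-type nitrogen, the scatter still holds in this assay once a six-membered aromatic ring with 1 hetero atom enters: the readings are a 1.9-fold lower number from compound 1 to compound 4 (0.29 log units; within the scatter) and a 1.9-fold lower number from compound 2 to compound 4 (0.27 log units; within the scatter) and a 1.4-fold lower number from compound 3 to compound 4 (0.14 log units; within the scatter) and none of these steps separates compound 4 from the others. So replacing a carbon-only aromatic ring with 5-chloropyridin-2-yl, which also brings 1 hydrogen-bond acceptor, gives a clearance number that cannot be told apart from those of compound 1, compound 2 or compound 3, even though the step from compound 1 also removes the three-membered ring. No measurement here speaks to why the clearance number of compound 4 falls where it does.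

As far as these compounds go, the role of the ring nitrogen on its own remains open, and a 4-chlorophenyl group on the same amide-type nitrogen would be the closest comparison for compound 4. From the compounds shown here alone, it is also open whether clearance would leave this narrow band with a non-aromatic group at this place, such as a morpholine, a carboxylic acid or a longer alkyl chain.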